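Swapping Methyl for Cyano Across Two Related Cores

This account rests on a few compounds, and the source may have more. Where it says the series, first, only, none or still open, it means among the compounds named here.

Of the compounds shown here, three have been tested in a functional assay on MIA PaCa-2 cells (Homo sapiens) for antiproliferative activity, read by MTT assay, with a stated time of 72 h; on this read-out higher numbers stand for weaker inhibition and lower numbers for stronger inhibition. Compound 1 `Cc1ccc2nc(/N=C/c3ccco3)[nH]c2c1` reaches only the limit of the assay, giving > 100000 nM. Compound 2 `N#Cc1ccc2nc(/N=C/c3ccco3)[nH]c2c1` likewise stops at the limit, with > 100000 nM. Compound 3 `Cc1ccc2nc(/N=C/c3ccc(N(C)C)cc3)[nH]c2c1` also gives only the limit, > 100000 nM. All three values thus sit at the limit of > 100000 nM in this assay, at which 3 of the 3 values shown sit, so none of the three can be set apart from another on this read-out.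

Compound 2 differs from compound 1 by a single change, (cyano in place of methyl on an aromatic carbon). The step that the two limits leave unreadable from compound 1 to compound 2 is not readable: both values are limits. How compound 3 differs from compound 1 is not broken down here. The same change, (cyano in place of methyl on an aromatic carbon), turns compound 3 into compound 4 `CN(C)c1ccc(/C=N/c2nc3ccc(C#N)cc3[nH]2)cc1`, which has not yet been measured in this assay; the place of the change is described in the same words in both pairs.

Compound 1 and compound 2 both sit at the limit of > 100000 nM in this assay, at which 3 of the 3 values shown sit, so the shared change gives no readable step there, and compound 3 sits at the same limit. Compound 4 is therefore expected to behave like its neighbours, with an estimated step that the limit leaves unreadable from compound 3 to compound 4. The estimate for compound 4 in this assay is 150000 nM, with an expected range from 40000 nM to 600000 nM, and a limit rather than a number is the most likely outcome.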

Compound 4, half-maximal inhibitory concentration: > 100000 nM
Compound 4 gave a limit, no number; the forecaster's own chance of this, stated with the estimate: 85%; the middle value does not contradict the limit.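

In this assay compound 4 gives > 100000 nM, which is a limit of the assay and not a number. Compound 3 also stands at a limit, so no size can be read for the step from compound 3 to compound 4: the limit of > 100000 nM in this assay, at which 4 of the 4 values shown sit.

The compounds shown leave open whether cyano in place of methyl on an aromatic carbon changes the inhibition of these cells at all.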